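Dropping one methoxy from a trimethoxyphenyl pyrazole chalcone

The source may hold more compounds than are shown below. What is called first, only, known or untested is meant among the compounds shown, and "the series" means these compounds.

Compound 1 `COc1ccc(-c2cc(/C=C/C(=O)c3ccc(N)cc3)[nH]n2)cc1` gives 9270 nM in a functional assay on NCI-H322M cells (Homo sapiens) for inhibition, read by sulforhodamine B assay, with a stated time of 48 h; on this read-out higher numbers stand for weaker inhibition of growth and lower numbers for stronger inhibition of growth. Compound 2 `COc1cc(-c2cc(/C=C/C(=O)c3ccc(N)cc3)[nH]n2)cc(OC)c1OC` gives 5590 nM in this assay. Compound 3 `COc1ccc(C(=O)/C=C/c2cc(-c3cc(OC)c(OC)c(OC)c3)n[nH]2)cc1` gives 4070 nM in this assay.

Compound 2 stands second highest of the three numbers. Among the measured compounds shown here, its nearest neighbour is compound 3, and the only single-point step on record, a 1.4-fold lower number from compound 2 to compound 3 (0.14 log units; within the scatter), exchanges the amino group of the aryl ketone for a methoxy group and stays within the scatter. For the measured compounds named here, compound 1 differs from compound 2 by more than one methoxy group on the aryl ring attached to the shared core, so no single step links them; their two values differ by an amount that is also within the scatter.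

Compound 4 `COc1ccc(-c2cc(/C=C/C(=O)c3ccc(N)cc3)[nH]n2)cc1OC` arises from compound 2 by hydrogen in place of methoxy on an aromatic carbon. Going by the values given here, no measured step removes a methoxy group from this ring, so the step from compound 2 to compound 3 bears on it only as a sign that small changes on the periphery have moved the number little. Compound 4 is therefore expected to land close to compound 2, if anything drifting toward compound 1, with an expected step of a 1.3-fold higher number from compound 2 to compound 4 (0.10 log units; within the scatter). The estimate for compound 4 is 7000 nM, within a range from 3500 nM to 14000 nM.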

Compound 4, concentration for total growth inhibition: 16500 nM
Beside the measured number, compound 4's estimate is 2.4-fold (0.37 log units) below it; measured number above the stated range.
By their numbers in this assay, from the lowest: compounds 3, 2, 1 and 4 (each within the scatter of the next, the first and the last beyond it).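

In this assay, among the compounds shown here, taking away the methoxy group that sits ortho to a methoxy group and meta to a large group gives a 3.0-fold higher number from compound 2 to compound 4 (0.47 log units; beyond the scatter) and so produces the first single-place change in this set to move the number beyond the scatter; the one earlier step, on the aryl ketone, stayed within it. The methoxy groups on this ring therefore do not all count alike, since placing a methoxy group in place of hydrogen on the same ring of compound 1 gives only a 1.8-fold higher number from compound 1 to compound 4 (0.25 log units; within the scatter) and leaves compound 1 and compound 4 within the scatter of each other, so that among these compounds only the step that ends at the trimethoxyphenyl ring of compound 2 separates two numbers. No measurement shown here offers an explanation for this difference between the two methoxy steps.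

On these data alone, what remains open is whether a hydroxy or ethoxy group on this aromatic carbon would keep the number near that of compound 2 or leave it near that of compound 4. As far as these compounds go, it is also open whether removing the same methoxy group from compound 3, which carries a methoxy group in place of the amino group, would give a step of similar size.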